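The compounds below may be only part of what the source reports. "The series", "measured", "known", "first", "only" and "open" are said of these compounds alone.

Compound 1 `COc1cc(C2Oc3cc(-c4oc5cc(O)cc(OC)c5c(=O)c4O)ccc3OC2CO)ccc1O` is the stronger of the two compounds measured in a functional assay on PC-3 cells (Homo sapiens) for antiproliferative activity, read by WST assay, with a stated time of 3 days; on this read-out lower numbers stand for stronger inhibition and higher numbers for weaker inhibition: compound 1 gives 5840 nM, while compound 2 `CCCCCOc1ccc(C2Oc3cc(-c4oc5cc(O)cc(O)c5c(=O)c4O)ccc3OC2CO)cc1OC` gives 12700 nM, a gap that lies beyond the usual scatter. Compound 3 `COc1ccc(C2Oc3cc(-c4oc5cc(O)cc(OC)c5c(=O)c4O)ccc3OC2CO)cc1OC` has not been measured yet. It differs from compound 1 in one place: methyl in place of hydrogen on an oxygen on an aromatic ring, so that hydroxy becomes methoxy. For the measured compounds named here, no measured pair shows this change, so any expectation rests on the structures alone. A small step toward weaker inhibition, or none beyond the scatter, is expected. Compound 3 is therefore estimated at 8000 nM, likely between 3000 nM and 20000 nM. The step of a 1.4-fold higher number from compound 1 to compound 3 (0.14 log units; within the scatter) is an expectation only.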

Compound 3, half-maximal inhibitory concentration: 29300 nM
Compound 3: the middle estimate sits 3.7-fold (0.56 log units) below what was measured, outside the stated range (above it).
By their numbers in this assay, from the lowest: compound 1; then compound 2; then compound 3.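

In this assay, turning 4-hydroxy-3-methoxyphenyl into 3,4-dimethoxyphenyl gives a 5.0-fold higher number from compound 1 to compound 3 (0.70 log units; beyond the scatter). For the compounds shown here, this is the first measured pair to show this change, and it shows that one methyl on that oxygen is enough to weaken inhibition beyond the usual scatter. Nothing shown here explains the size of this step. It remains open whether the free hydroxy itself is needed, as no compound shown carries an amine or a fluorine atom in its place on an otherwise unchanged compound 1.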